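Side-chain amine substitution in the diketone series: compound 3

The source may hold more compounds than are shown below. What is called first, only, known or untested is meant among the compounds shown, and "the series" means these compounds.

Measured so far:
compound 1, `COc1cccc(-c2c(C)n(Cc3c(F)cccc3F)c(=O)n(C[C@@H](N)C3CCCC3)c2=O)c1F`: 94 nM
compound 2, `COc1cccc(-c2c(C)n(Cc3c(F)cccc3F)c(=O)n(C[C@H](N)C(C)C)c2=O)c1F`: 51 nM

In an assay on HEK293 cells for binding affinity to Gonadotropin-releasing hormone receptor (Homo sapiens), read by radioligand binding (on this read-out lower numbers stand for stronger inhibition and higher numbers for weaker inhibition), compound 2 gives 51 nM, the lower of the two numbers. Compound 1 gives 94 nM in this assay, and the step of a 1.8-fold lower number from compound 1 to compound 2 (0.27 log units; within the scatter) is within the scatter, so the two compounds cannot be ordered on these data.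

Compound 3, `CN[C@H](CC(C)C)Cn1c(=O)c(-c2cccc(OC)c2F)c(C)n(Cc2c(F)cccc2F)c1=O`, differs from compound 2 by 3-methyl-1-(methylamino)butyl in place of 1-amino-2-methylpropyl on a saturated chain carbon bound to an aromatic nitrogen. Within the data shown here, the one measured step, a 1.8-fold lower number from compound 1 to compound 2 (0.27 log units; within the scatter), varies the group on that same carbon while keeping the primary amine unchanged, and it was within the scatter. Among the measured compounds shown here, no measured pair alters the amine itself or lengthens the chain by the one carbon involved here, so that step bears on the present change only loosely. Without a relevant step beyond the scatter, no shift beyond the scatter is expected in this assay.

For compound 3 the estimated value in this assay is 60 nM. The expected range for compound 3 runs from 20 nM to 200 nM. For compound 3 this amounts to an expected step of a 1.2-fold higher number from compound 2 to compound 3 (0.07 log units; within the scatter).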

Compound 3, inhibition constant: 1.2 nM
Compound 3: middle estimate off by 50-fold (1.70 log units), on the high side; the measured number lies below the stated range.
By their numbers in this assay, from the lowest: compound 3; then compounds 2 and 1 (each within the scatter of the next).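

In this assay, the group on the saturated chain carbon bound to an aromatic nitrogen proves far more sensitive than the earlier pair suggested, since 3-methyl-1-(methylamino)butyl in place of 1-amino-2-methylpropyl gives a large step (a 43-fold lower number from compound 2 to compound 3 (1.63 log units; beyond the scatter)). The step from the amino(cyclopentyl)methyl compound is of similar order (a 78-fold lower number from compound 1 to compound 3 (1.89 log units; beyond the scatter)), so compound 3 stands clearly apart from both earlier compounds, which remain within the scatter of each other. No supporting evidence is available to explain this gain in binding affinity.

The change combines a methylamino group in place of a primary amine with a longer branched side chain, so these compounds cannot show how much of the step belongs to each feature. A primary amine on the 3-methylbutyl chain and a methylamino group on the 2-methylpropyl chain would separate the two, while a dimethylamino group or a still longer chain leaves open how far the trend extends.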